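Sulfamate series: amine swap on the benzamide ring

The source may hold more compounds than are shown below. What is called first, only, known or untested is meant among the compounds shown, and "the series" means these compounds.

Measured compounds:
compound 1 `CN(C)CCN(CCN(C)C)c1cccc(C(=O)N2CCc3ccc(OS(N)(=O)=O)cc3C2)c1` — 17.1%
compound 2 `CCN(Cc1ccccn1)c1cccc(C(=O)N2CCc3ccc(OS(N)(=O)=O)cc3C2)c1` — 19.9%
compound 3 `NS(=O)(=O)Oc1ccc2c(c1)CN(C(=O)c1cccc(N3CCc4ccccc4C3)c1)CC2` — 50.2%

All three share the same core and differ only in the amine on the benzamide ring. In an assay on HEK293 cells for inhibition of Steryl-sulfatase (Homo sapiens), tested at 1 uM (on this read-out higher numbers stand for a stronger effect at the one concentration tested and lower numbers for a weaker effect), compound 3 gives the highest number of the three, with a number 33.1 percentage points higher from compound 1 to compound 3 (beyond the scatter) and a number 30.3 percentage points higher from compound 2 to compound 3 (beyond the scatter) both clearly beyond the scatter, so compound 3 is the strongest here. Compound 1 and compound 2 sit close together, a number 2.8 percentage points higher from compound 1 to compound 2 (within the scatter) lying within the scatter.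

Compound 4 `CCN(Cc1ccncc1)c1cccc(C(=O)N2CCc3ccc(OS(N)(=O)=O)cc3C2)c1` has not yet been measured in this assay. Its change from compound 3: ethyl((pyridin-4-yl)methyl)amino in place of 1,2,3,4-tetrahydroisoquinolin-2-yl on an aromatic carbon

The step that bears on this is a number 30.3 percentage points higher from compound 2 to compound 3 (beyond the scatter), since compound 2 carries the ethyl((pyridin-2-yl)methyl)amino group and compound 4 the ethyl((pyridin-4-yl)methyl)amino group, both open amines replacing the 1,2,3,4-tetrahydroisoquinolin-2-yl group. Compound 1, with the bis(2-(dimethylamino)ethyl)amino group, also falls far below compound 3 in this assay. A large drop is therefore expected going from compound 3 to compound 4, about a number 29.2 percentage points lower from compound 3 to compound 4 (beyond the scatter), because compound 2 gives 19.9%.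

Compound 4 is expected to give roughly 21% in this assay, within a range of 8% to 38%.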

Compound 4, a percentage reported as inhibition, at one concentration (the size of the read-out at that concentration, not a potency): 52.8%
Compound 4: the middle estimate sits 31.8 percentage points below what was measured, outside the stated range (above it).
By their numbers in this assay, from the lowest: compounds 1 and 2 (each within the scatter of the next); then compounds 3 and 4 (each within the scatter of the next).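

In this assay, the open amine at this position is not in itself what lowers the number: with the ethyl group and the methylene link unchanged, pyridin-4-yl in place of pyridin-2-yl gives a number 32.9 percentage points higher from compound 2 to compound 4 (beyond the scatter), so the low value of compound 2 belongs to the pyridin-2-yl form and not to open amines as a class. The 1,2,3,4-tetrahydroisoquinolin-2-yl ring is also not required, since replacing it with ethyl((pyridin-4-yl)methyl)amino gives a number 2.6 percentage points higher from compound 3 to compound 4 (within the scatter), while the replacement of bis(2-(dimethylamino)ethyl)amino by the same group gives a number 35.7 percentage points higher from compound 1 to compound 4 (beyond the scatter), which leaves compound 1 as an open amine that stays low and compound 4 as one that does not. No measurement at hand explains the difference between the two pyridine forms.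

Going by these compounds, it remains open whether pyridin-3-yl on the same chain carbon would fall with pyridin-4-yl or with pyridin-2-yl, and whether a plain phenyl ring would do as well as either. On these data alone, it is also open whether methyl or propyl in place of the ethyl group would hold the value seen for compound 4, and a single-concentration read-out cannot rank the potencies of compound 3 and compound 4.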